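Removing the Ethoxy Group from an Anilino Side Chain

The source may report more compounds than this note shows. Statements on the series, on what has been measured and on what is new or still open speak of the compounds shown alone.

Three measured compounds share one core and differ only in the group on the amine nitrogen. Compound 1 `O=C1C(NC2CC2)=CC(=O)c2c1nc1n2[C@H]2OC[C@@H](O)[C@H]2OC1` carries a cyclopropyl there, and in a functional assay on MGC-803 cells (Homo sapiens) for inhibition, read by sulforhodamine B assay (on this read-out higher numbers stand for weaker inhibition and lower numbers for stronger inhibition), compound 1 returns only a limit, > 4000 nM. Compound 2 `COc1ccc(NC2=CC(=O)c3c(nc4n3[C@H]3OC[C@@H](O)[C@H]3OC4)C2=O)cc1` carries a 4-methoxyphenyl and gives 2150 nM in this assay. Compound 3 `CCOc1ccccc1NC1=CC(=O)c2c(nc3n2[C@H]2OC[C@@H](O)[C@H]2OC3)C1=O` carries a 2-ethoxyphenyl and gives 2830 nM; it stands highest of the two numbers, with compound 2 the nearest, the step being a 1.3-fold higher number from compound 2 to compound 3 (0.12 log units; within the scatter). The moves from cyclopropyl to an aryl group read an at least 1.8-fold lower number from compound 1 to compound 2 (0.26 log units; that floor lies within the scatter) and an at least 1.4-fold lower number from compound 1 to compound 3 (0.15 log units; that floor lies within the scatter), and both rest on a limit, (the limit of > 4000 nM in this assay, at which 1 of the 3 values shown sits).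

Compound 4 `O=C1C(Nc2ccccc2)=CC(=O)c2c1nc1n2[C@H]2OC[C@@H](O)[C@H]2OC1` is not yet measured. It differs from compound 3 in one place: hydrogen in place of ethoxy on an aromatic carbon. The two aryl compounds already sit within the scatter of each other, so the aryl substituent has shown no effect beyond the scatter so far. The expected step is therefore a 1.1-fold lower number from compound 3 to compound 4 (0.04 log units; within the scatter), nothing beyond the scatter. For compound 4 the estimate in this assay is 2600 nM, between 1200 nM and 6000 nM.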

Compound 4, half-maximal inhibitory concentration: 1830 nM
Estimate against measurement, compound 4: 1.4-fold (0.15 log units) above; the range from low to high includes it.
By their numbers in this assay, from the lowest: compounds 4, 2 and 3 (each within the scatter of the next). At a limit, above all of these: compound 1.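

On the aromatic ring, hydrogen in place of ethoxy gives a 1.5-fold lower number from compound 3 to compound 4 (0.19 log units; within the scatter), and hydrogen in place of methoxy gives a 1.2-fold lower number from compound 2 to compound 4 (0.07 log units; within the scatter), so in this assay neither alkoxy group is shown to matter, and the plain phenyl stays level with the substituted aryl compounds. Phenyl in place of cyclopropyl gives the only step on this amine nitrogen that clears the scatter, an at least 2.1-fold lower number from compound 1 to compound 4 (0.33 log units; beyond the scatter). That step is a floor, and it rests on the limit of compound 1: the limit of > 4000 nM in this assay, at which 1 of the 4 values shown sits.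

The compounds shown leave open whether a chlorine, an amine or a carboxylic acid on the phenyl ring would move the number beyond the scatter. They also leave open whether a benzyl group or a longer alkyl chain on the nitrogen would read like phenyl or like cyclopropyl.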